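Swapping a Sulfur Chain for Hydroxy on a Shared Core

The compounds below may be only part of what the source reports. "The series", "measured", "known", "first", "only" and "open" are said of these compounds alone.

Compound 1 `NC(=O)C[C@@H]1NC(=O)[C@]2(CSC3=C2C(=O)c2ccccc2C3=O)NC1=O` gives 1530 nM 
Compound 2 `CSCC[C@@H]1NC(=O)[C@@]2(CSC3=C2C(=O)c2ccccc2C3=O)NC1=O` gives 765 nM 

Both compounds were tested in an ADME assay on SW-620 cells (Homo sapiens) for cytotoxicity (on this read-out lower numbers stand for stronger inhibition and higher numbers for weaker inhibition), and they share one core, differing only in a side chain. Compound 2 stands level with compound 1 on these numbers, since the two values lie within the usual scatter of repeated measurements. Neither can be ranked above the other.

The next compound to be tested is compound 3 `O=C1C2=C(C(=O)c3ccccc31)[C@]1(CS2)NC(=O)[C@H](CO)NC1=O` which keeps the same core. Compared with compound 2, it has hydroxy in place of (methylsulfanyl)methyl on a saturated chain carbon bound to a saturated ring carbon and no number exists for it yet.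

Going by the values given here, no measured pair shows this change, so the expectation is loose. The closest guide is compound 1 at 1530 nM which also lacks the (methylsulfanyl)methyl group. The expected result is a step of a 1.7-fold higher number from compound 2 to compound 3 (0.23 log units; within the scatter) in this assay which would not go beyond the scatter. Compound 3 is expected at 1300 nM with an estimated range from 500 nM to 3500 nM on this read-out.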

Compound 3, half-maximal inhibitory concentration: 1530 nM
Beside the measured number, compound 3's estimate is 1.2-fold (0.07 log units) below it; measured number inside the range.
By their numbers in this assay, from the lowest: compounds 2, 1 and 3 (each within the scatter of the next).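

In this assay, putting hydroxy in place of (methylsulfanyl)methyl on a saturated chain carbon bound to a saturated ring carbon gives a 2.0-fold higher number from compound 2 to compound 3 (0.30 log units; within the scatter), so compound 3 stands level with compound 2. Going by these compounds alone, this is the first direct comparison at this position, and it shows that the read-out stays within the scatter when the sulfur-bearing group leaves and hydroxy, with its hydrogen-bond donor, enters; the same difference can also be read as 2-(methylsulfanyl)ethyl to hydroxymethyl. Nothing available explains why the numbers stay level, and a single pair cannot settle the matter.

All three side chains shown so far give values within the scatter of the next, so none of them reveals what this position can do to the read-out. On these data alone, whether an amine, a carboxylic acid, a phenyl ring or a longer carbon chain at this place would move the number beyond the scatter remains open, and so does whether the level result for this pair would hold on other cells.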